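Thiophenyl back in place of pyridinyl, with a methyl added

The source may report more compounds than this note shows. Statements on the series, on what has been measured and on what is new or still open speak of the compounds shown alone.

Compound 1 `O=C(O)CCc1ccc(C#Cc2cccs2)cc1` reaches 97% in an in vitro functional assay on 1321-N1 cells for agonist activity at Free fatty acid receptor 1 (Homo sapiens), read by fluorescence, spectrophotometry and calcium flux; on this read-out lower numbers stand for smaller maximal responses and higher numbers for larger maximal responses. Compound 2 `O=C(O)CCc1ccc(C#Cc2ccccn2)cc1`, in which pyridin-2-yl replaces thiophen-2-yl on the triple-bonded carbon, gives 98% in this assay; the step of a number 1 percentage points higher from compound 1 to compound 2 (within the scatter) is within the scatter, so the two compounds sit together near a full response and neither can be called the larger. Compound 3 `Cc1ccsc1C#Cc1ccc(CCC(=O)O)cc1` differs from compound 2 by 3-methylthiophen-2-yl in place of pyridin-2-yl on a triple-bonded carbon. For the measured compounds named here, the only step that bears on this change is the swap between compound 1 and compound 2, and that step was within the scatter, so a thiophene ring in place of the pyridine is not expected to move the maximal response; the added methyl has no precedent among the measured compounds. Compound 3 is therefore expected to give 95%, with a range from 80% to 105%. The expected step is a number 3 percentage points lower from compound 2 to compound 3 (within the scatter), nothing beyond the scatter.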

Compound 3, largest response reached (reported as efficacy), in percent of the reference or control that the assay uses: 100%
Beside the measured number, compound 3's estimate is 5 percentage points below it; the measured number falls inside the stated range.
By their numbers in this assay, from the lowest: compounds 1, 2 and 3 (each within the scatter of the next).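

The step that isolates the added methyl reads a number 3 percentage points higher from compound 1 to compound 3 (within the scatter), so in this assay a methyl in place of hydrogen on this aromatic carbon of the thiophene does not separate the two compounds. The combined replacement of pyridin-2-yl by 3-methylthiophen-2-yl on the triple-bonded carbon reads a number 2 percentage points higher from compound 2 to compound 3 (within the scatter), so the ring swap and the methyl taken together also leave the maximal response unresolved from that of the pyridine compound. Nothing available explains this result or bears on it.

Going by these compounds, whether an ethyl, a methoxy or an amine in place of that methyl would keep the response in the same range remains open. Also open, on these data alone, is whether a carboxylic acid chain other than the propanoic acid of the shared core would do so.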